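This account rests on a few compounds, and the source may have more. Where it says the series, first, only, none or still open, it means among the compounds named here.

Among the measured compounds shown here, compound 2 `CSCC[C@H](NC(=O)CN(c1nc(Cl)nc2[nH]cnc12)C1CC1)C(=O)O` holds the lower of the two numbers so far: in a functional assay on the whole organism (Tail, strain ICR) with Mus musculus as the target, in the tail flick test, with a stated time of 120 min, at a dose of 25 umol/kg by the oral route (on this read-out lower numbers stand for a weaker effect and higher numbers for a stronger effect at the one dose given), compound 2 gives 5.67%, while compound 1 `CC[C@H](C)[C@H](NC(=O)CN(c1nc(Cl)nc2[nH]cnc12)C1CC1)C(=O)O` gives 21.4%. For the measured compounds named here, the one step that joins them, a number 15.7 percentage points lower from compound 1 to compound 2 (beyond the scatter), is the only measured step in this set. Compound 3 `NC(=O)CC[C@H](NC(=O)CN(c1nc(Cl)nc2[nH]cnc12)C1CC1)C(=O)O` differs from compound 2 in a single place: carbamoyl in place of methylsulfanyl on a saturated chain carbon, three bonds along the chain from an amide-type nitrogen and a carbonyl carbon. Going by the values given here, no measured step exchanges methylsulfanyl for carbamoyl, so the step from compound 1 to compound 2 bears on it only in that it altered the same side chain, and it was a modest step downward. With compound 2 already the lowest value seen, there is little room below, and a step of no more than the scatter, or a small rise, is expected for compound 3, namely a number 4.3 percentage points higher from compound 2 to compound 3 (within the scatter). Compound 3 is therefore estimated at 10% in this assay, with a range from 0% to 28%.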

Compound 3, a percentage reported as activity, at one dose (the size of the read-out at that dose, not a potency): 17.8%
Estimate against measurement, compound 3: 7.8 percentage points below; the range from low to high includes it.
By their numbers in this assay, from the lowest: compound 2; then compounds 3 and 1 (each within the scatter of the next).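

Carbamoyl in place of methylsulfanyl, on a saturated chain carbon three bonds along the chain from an amide-type nitrogen and a carbonyl carbon, gives a number 12.1 percentage points higher from compound 2 to compound 3 (beyond the scatter) in this assay, so this side chain can move the read-out upward as well as downward. The change from sec-butyl to 2-carbamoylethyl gives a number 3.6 percentage points lower from compound 1 to compound 3 (within the scatter), which places two differently built side chains level, while among these three compounds only the 2-(methylsulfanyl)ethyl chain of compound 2 stands apart from both others. Nothing available explains why these side chains give these results.

On these data alone, whether a carboxylic acid or an amine at the end of this chain would match the carbamoyl group remains open. So does whether a longer chain bearing the carbamoyl group would hold the level of compound 3.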